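Phenylcarbamoyl to (4-cyanophenyl)sulfonyl: stability outlook

The compounds below may be only part of what the source reports. "The series", "measured", "known", "first", "only" and "open" are said of these compounds alone.

Three compounds of the series have been run in an ADME assay on microsomes from liver (Homo sapiens) for metabolic stability, read by LC-MS, with NADPH named in the record, with a stated time of 60 min, tested at 1 uM, in the absence of a further agent; on this read-out higher numbers stand for a more stable compound and lower numbers for a less stable compound. Compound 1 `COc1cc(-c2c(C)nc3c(N4CC[C@@H](NC(C)=O)C4)cc(C)nn23)ccc1F` sits at a limit of the assay, giving > 95%. Compound 2 `COc1ccc(-c2c(C)nc3c(N4CC[C@@H](NC(C)=O)C4)cc(C)nn23)cc1F` likewise reports only a limit, at > 95%. The step that the two limits leave unreadable from compound 1 to compound 2 therefore cannot be sized. Compound 3 `COc1ccc(-c2c(C)nc3c(N4CC[C@@H](NC(=O)Nc5ccccc5)C4)cc(C)nn23)cc1OC` also returns only a limit, > 95%. With all three values at the limit of > 95% in this assay, at which 3 of the 3 values shown sit, compound 3 cannot be placed relative to the others beyond the statement that it is as stable as this assay can register.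

Compound 4 `COc1ccc(-c2c(C)nc3c(N4CC[C@@H](NS(=O)(=O)c5ccc(C#N)cc5)C4)cc(C)nn23)cc1OC` differs from compound 3 in one place: (4-cyanophenyl)sulfonyl in place of phenylcarbamoyl on an amine nitrogen. Going by the values given here, no measured step bears on this change; the only step available concerns a different place and is itself unreadable. Nothing measured shows a loss of stability anywhere in the series, and nothing shows how far beyond the limit compound 3 actually lies, so the step from compound 3 to compound 4 is expected to be a number at least 5 percentage points lower from compound 3 to compound 4 (that floor lies within the scatter), none beyond the scatter. Compound 4 is expected to stay near the top of the scale in this assay, with an estimate of 90% and a range from 70% to 99%, and a reading that is again only a limit is the more likely outcome.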

Compound 4, percent of the compound remaining: > 95%
Compound 4 was reported as a limit (the forecaster's own chance of this, stated with the estimate: 60%); middle value at least 5 percentage points away from the limit.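

In this assay compound 4 gives > 95%, again only a limit. No step can be read between compound 3 and compound 4, as both readings are limits: the limit of > 95% in this assay, at which 4 of the 4 values shown sit.

The compounds shown leave open how far compound 3 and compound 4 differ in stability, and which change to the series, if any, would bring a reading off this limit.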